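Demethylation of a Trimethoxy Styryl Butenolide

The compounds below may be only part of what the source reports. "The series", "measured", "known", "first", "only" and "open" are said of these compounds alone.

Of the compounds shown here, three sharing a styryl butenolide core have been measured in a functional assay on NCI/ADR-RES cells (Homo sapiens) for inhibition, read by sulforhodamine B assay, with a stated time of 48 h; a higher number here means a weaker inhibitor of growth, a lower number a stronger inhibitor of growth. Compound 1 `COc1ccc(/C=C/C2(C)C=CC(=O)O2)c(OC)c1` gives 151000 nM, compound 2 `COc1ccc(/C=C/C2(C)C=CC(=O)O2)cc1OC` gives 111000 nM, and compound 3 `COc1ccc(/C=C/C2(C)C=CC(=O)O2)c(OC)c1OC` gives 349000 nM. Compound 3 stands highest of the three, as its number is raised by a 2.3-fold higher number from compound 1 to compound 3 (0.36 log units; beyond the scatter) and by a 3.1-fold higher number from compound 2 to compound 3 (0.50 log units; beyond the scatter), both steps adding a methoxy in place of hydrogen on an aromatic carbon, and both judged beyond the scatter.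

Compound 4 `COc1c(O)ccc(/C=C/C2(C)C=CC(=O)O2)c1OC` differs from compound 3 by hydrogen in place of methyl on an oxygen on an aromatic ring. Neither measured step bears directly on this change: the two steps known concern the entry of a methoxy group onto a ring carbon, not the removal of a methyl from an oxygen already present. Within the data shown here, with no guiding step, the expectation for compound 4 in this assay is a number close to that of compound 3, with a step of a 1.2-fold lower number from compound 3 to compound 4 (0.07 log units; within the scatter) lying within the scatter. Compound 4 is therefore estimated at 300000 nM, with a range from 110000 nM to 800000 nM.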

Compound 4, concentration for total growth inhibition: 51600 nM
Beside the measured number, compound 4's estimate is 5.8-fold (0.76 log units) above it; the whole stated range lies above it.
By their numbers in this assay, from the lowest: compound 4; then compounds 2 and 1 (each within the scatter of the next); then compound 3.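

Exchanging methoxy for hydroxy, with only a methyl leaving an oxygen on the aromatic ring, gives a 6.8-fold lower number from compound 3 to compound 4 (0.83 log units; beyond the scatter) in this assay, so the number is sensitive to what sits on this oxygen. The earlier steps shown here showed only that a methoxy in place of hydrogen on an aromatic carbon raised the number, whereas this change at an oxygen already present moves it the other way. Nothing available accounts for this shift.

As far as these compounds go, whether the lower number belongs to the hydroxy itself, or would also follow from an amine or a fluorine in its place, remains open. From the compounds shown here alone, it is equally open whether turning one of the other methoxy groups of compound 3, or those of compound 1 and compound 2, into a hydroxy would lower the number in the same way.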